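This account rests on a few compounds, and the source may have more. Where it says the series, first, only, none or still open, it means among the compounds named here.

Measured in an ADME assay on CCRF-HSB-2 cells (Homo sapiens) for cytotoxicity, with a stated time of 7 days; a higher number here means that more compound is tolerated, a lower number that less compound is tolerated:
Compound 1 `COCCOc1nc(N)nc2c1ncn2/C=C1/CC1(CO)CO` gives > 20000 nM, which is a limit
Compound 2 `CCCCCCSc1nc(N)nc2c1ncn2/C=C1/CC1(CO)CO` gives 60000 nM

Among the compounds with values here, compound 2, at 60000 nM, carries the only actual number in this assay. Compound 1 is known only through its limit, (the limit of > 20000 nM in this assay, at which 1 of the 2 values shown sits).

Compound 3 `Nc1nc(SC2CCCC2)c2ncn(/C=C3/CC3(CO)CO)c2n1` departs from compound 2 in one place: cyclopentyl in place of hexyl on a sulfur. Within the data shown here, the one measured step that touches this sulfanyl position is a step that the limit leaves unreadable from compound 1 to compound 2, so it offers no size to carry over. With compound 2 at 60000 nM as the sole anchor, no step beyond the scatter is expected, in either direction. This amounts to an expected 1.2-fold lower number from compound 2 to compound 3 (0.08 log units; within the scatter). Compound 3 is estimated at 50000 nM, with an expected range of 20000 nM to 120000 nM.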

Compound 3, half-maximal cytotoxic concentration: 91000 nM
The estimate for compound 3 lay 1.8-fold (0.26 log units) below the measured number; the range from low to high includes it.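

In this assay, exchanging the open hexyl chain on the sulfur for the cyclopentyl ring gives a 1.5-fold higher number from compound 2 to compound 3 (0.18 log units; within the scatter). Within the data shown here, this is the first step at this position that can be read, and it shows that a chain can give way to a five-membered ring of carbon only without a shift beyond the usual scatter. The steps that start from compound 1, whose value is a limit, cannot be read: the limit of > 20000 nM in this assay, at which 1 of the 3 values shown sits.

The compounds shown leave open whether a group on this sulfur that is not a plain carbon group, such as a chain ending in an amine or a carboxylic acid, would move the number beyond the scatter. They also leave open how a phenyl ring on the sulfur would compare with the hexyl and cyclopentyl groups.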